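A few compounds are considered here, and "the series" means these few. Any claim that something is new, unique, unknown or untested is made for them only; others in the source may bear on it.

Compound 1, `COc1cc2oc(-c3cccc(NC(=O)c4ccccc4)c3)cc(=O)c2c(OC)c1OC`: 11700 nM
Compound 2, `COc1cc2oc(-c3cccc(NC(=O)c4ccccc4Br)c3)cc(=O)c2c(OC)c1OC`: 23100 nM
Compound 3, `COc1cc2oc(-c3cccc(NC(=O)c4ccc(F)cc4)c3)cc(=O)c2c(OC)c1OC`: 47200 nM

These three compounds share the same core and differ only in the benzoyl part that sits on the amide nitrogen. In a functional assay on HepG2 cells (Homo sapiens) for inhibition, read by MTT assay (on this read-out lower numbers stand for stronger inhibition of growth and higher numbers for weaker inhibition of growth), compound 1 gives 11700 nM, the lowest number of the three. The gap to compound 2 is small: a 2.0-fold higher number from compound 1 to compound 2 (0.30 log units; within the scatter). The gap to compound 3 is larger: a 4.0-fold higher number from compound 1 to compound 3 (0.61 log units; beyond the scatter), a modest loss in growth inhibition.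

Compound 4, `COc1cc2oc(-c3cccc(NC(=O)c4ccc([N+](=O)[O-])cc4)c3)cc(=O)c2c(OC)c1OC`, has not yet been measured in this assay. It differs from compound 1 by nitro in place of hydrogen on an aromatic carbon. Both measured steps bear on this change, since each also replaces a hydrogen on the benzoyl ring by another group, and each raised the number; the fluoro step in compound 3, which sits at the same place on the ring as the nitro group in compound 4, is the closer guide. From these two steps a modest rise in the number is expected for compound 4, roughly a 2.4-fold higher number from compound 1 to compound 4 (0.38 log units; beyond the scatter). The estimate for compound 4 in this assay is 28000 nM, with a range from 11000 nM to 70000 nM.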

Compound 4, concentration for 50% growth inhibition: 18800 nM
Compound 4: middle estimate off by 1.5-fold (0.17 log units), on the high side, within the range that was stated.
By their numbers in this assay, from the lowest: compounds 1, 4 and 2 (each within the scatter of the next); then compound 3.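

In this assay, a nitro group para to a large group on the benzoyl ring gives a 1.6-fold higher number from compound 1 to compound 4 (0.21 log units; within the scatter) and so leaves compound 4 indistinguishable from the unsubstituted compound 1. The same place holding a different group gives a different outcome, with a 2.5-fold lower number from compound 3 to compound 4 (0.40 log units; beyond the scatter) showing that the loss seen with fluoro does not follow from simply replacing this hydrogen, since the identity of the incoming group matters. Compound 2 cannot be separated from compound 4, as a 1.2-fold lower number from compound 2 to compound 4 (0.09 log units; within the scatter) shows, and nothing measured here explains why nitro and fluoro part ways at this place.

Going by these compounds, with only hydrogen, fluoro and nitro compared at this place, it remains open how a group of another kind, such as an amine, a carboxylic acid or a methoxy group, would behave there, and whether any of them would give a number clearly lower than that of compound 1. On these data alone, it also remains open whether a nitro group would give the same result at the place on the ring held by the bromo group in compound 2.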